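Methyl on the Amide Nitrogen of Compound 1

The source may report more compounds than this note shows. Statements on the series, on what has been measured and on what is new or still open speak of the compounds shown alone.

Measured in a functional assay on MDA-MB-231 cells (Homo sapiens), read by microscopy and transwell migration, with a stated time of 24 h; on this read-out higher numbers stand for weaker inhibition and lower numbers for stronger inhibition:
Compound 1 `COc1cc(-c2csc(NC(=O)c3ccccc3)n2)cc(OC)c1OC`: > 50000 nM (a limit)
Compound 2 `COc1ccc(C(=O)Nc2nc(-c3cc(OC)c(OC)c(OC)c3)cs2)cc1`: > 25000 nM (a limit)
Compound 3 `COc1cc(-c2csc(NC(=O)c3cccc(OC)c3OC)n2)cc(OC)c1OC`: 15000 nM

Compound 1 stands only as a limit, > 50000 nM, and not as a number. Compound 2 is also only a limit, > 25000 nM. Compound 3 alone has a measured number, 15000 nM.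

Compound 4 `COc1cc(-c2csc(N(C)C(=O)c3ccccc3)n2)cc(OC)c1OC` keeps the core of compound 1 and differs from it by methyl in place of hydrogen on an amide-type nitrogen.

Among the measured compounds shown here, no measured step touches that nitrogen, so the evidence is indirect. All three steps lie on the carbonyl side. For the measured compounds named here, putting 2,3-dimethoxyphenyl in place of phenyl on a carbonyl carbon gave an at least 3.3-fold lower number from compound 1 to compound 3 (0.52 log units; beyond the scatter), the one step beyond the scatter. The companion change gave an at least 1.6-fold lower number from compound 2 to compound 3 (0.22 log units; that floor lies within the scatter), whose floor lies within the scatter, and methoxy in place of hydrogen gave a step that the two limits leave unreadable from compound 1 to compound 2.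

In this assay, a single change can therefore move compound 1 to a lower number, as compound 3 shows with 15000 nM. A modest move in that direction is expected here too, though compound 4 may yet return only a limit. The expected step is an at least 3.3-fold lower number from compound 1 to compound 4 (0.52 log units; beyond the scatter). Compound 4 is estimated at 15000 nM, with an expected range of 1000 nM to 60000 nM.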

Compound 4, half-maximal inhibitory concentration: 10000 nM
Estimate against measurement, compound 4: 1.5-fold (0.18 log units) above; measured number inside the range.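

In this assay, methyl in place of hydrogen on an amide-type nitrogen gave an at least 5.0-fold lower number from compound 1 to compound 4 (0.69 log units; beyond the scatter), which shows that this nitrogen is also a place where the number responds, whereas every earlier step lay on the carbonyl side. The change enters only 1 heavy atom and leaves the phenyl on the carbonyl carbon as it stands in compound 1, so the number can fall with no change on the carbonyl side at all. The size of this step is a floor and not a measured size, because compound 1 stands only as a limit: the limit of > 50000 nM in this assay, at which 1 of the 4 values shown sits.

The compounds shown do not tell whether the step belongs to the methyl itself or to the loss of the amide hydrogen, and an ethyl or a longer chain on the same nitrogen would be needed to show how the number follows the size of the group there. They also leave open whether methyl on this nitrogen and the 2,3-dimethoxyphenyl on the carbonyl carbon of compound 3 would add up when carried together in one compound.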